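The compounds below may be only part of what the source reports. "The series", "measured", "known", "first", "only" and "open" are said of these compounds alone.

Among the compounds with values here, compound 3 `CCCCCCCCS(=O)(=O)Nc1ccc(-c2cccc(F)c2)cc1C(=O)O` gives 37600 nM in an assay on mitochondria (strain BALB/c) for inhibition of glycerol-3-phosphate acyltransferase 1, mitochondrial (Mus musculus), read by scintillation counting, with a stated time of 10 min (a higher number here means a weaker inhibitor, a lower number a stronger inhibitor), the highest number of the three measured so far; compound 2 `CCCCCCCCS(=O)(=O)Nc1ccc(-c2ccccc2OC)cc1C(=O)O` with 27600 nM lies within the scatter of it, while compound 1 `CCCCCCCCS(=O)(=O)Nc1cc(-c2ccc(OC)cc2)ccc1C(=O)O` with 13300 nM lies beyond it. Compound 4 `CCCCCCCCS(=O)(=O)Nc1ccc(CCc2ccc(OC)cc2)cc1C(=O)O` is still to be measured; the change from compound 3 is 2-(4-methoxyphenyl)ethyl in place of 3-fluorophenyl on an aromatic carbon. Within the data shown here, the only measured step at this position is a 1.4-fold higher number from compound 2 to compound 3 (0.13 log units; within the scatter), an aryl swap that stayed within the scatter. Among the measured compounds shown here, no measured step tests the ethyl link that enters here, so its effect is unknown. Compound 4 is therefore expected to give about 30000 nM in this assay, with a range of 9000 nM to 100000 nM. The expected step is a 1.3-fold lower number from compound 3 to compound 4 (0.10 log units; within the scatter), not beyond the scatter.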

Compound 4, half-maximal inhibitory concentration: 26300 nM
Compound 4: the middle estimate sits 1.1-fold (0.06 log units) above what was measured; the measured number falls inside the stated range.
By their numbers in this assay, from the lowest: compounds 1, 4, 2 and 3 (each within the scatter of the next, the first and the last beyond it).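

In this assay, adding the ethyl link at this position leaves the number within the scatter: the change gives a 1.4-fold lower number from compound 3 to compound 4 (0.16 log units; within the scatter), and the comparison with the directly attached 2-methoxyphenyl gives a 1.0-fold lower number from compound 2 to compound 4 (0.02 log units; within the scatter). Among compound 2, compound 3 and compound 4, a directly attached aryl ring and one carried on the ethyl link therefore cannot be told apart. No evidence bears on why this is so.

Going by these compounds, it remains open whether a longer chain as the link, or an amine within it, would move the number beyond the scatter.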